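This account rests on a few compounds, and the source may have more. Where it says the series, first, only, none or still open, it means among the compounds named here.

Compound 1 `COc1cc(-c2ccnc3cc(-c4ccc(C)cc4)nn23)cc(OC)c1OC`: 3 nM
Compound 2 `COc1ccc(-c2cc3nccc(-c4cc(OC)c(OC)c(OC)c4)n3n2)cc1[N+](=O)[O-]`: > 10000 nM

In a functional assay on A549 cells (Homo sapiens) for inhibition, read by CCK-8 assay, with a stated time of 48 h (a lower number here means a stronger inhibitor, a higher number a weaker inhibitor), compound 1 gives the only number among these values, namely 3 nM. Compound 2 in this assay gives only a limit of the assay, > 10000 nM, which is the limit of > 10000 nM in this assay, at which 1 of the 2 values shown sits. Within the data shown here, no two measured compounds differ in one place only, so no measured step between them exists. Compound 3 `COc1cc(-c2ccnc3cc(-c4ccc5ccn(C)c5c4)nn23)cc(OC)c1OC` carries 1-methyl-1H-indol-6-yl in place of 4-methylphenyl on an aromatic carbon. A small loss is expected from this change, a 3.3-fold higher number from compound 1 to compound 3 (0.52 log units; beyond the scatter), near the edge of the usual scatter. For compound 3 the estimate in this assay is 10 nM, expected to fall between 2 nM and 60 nM.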

Compound 3, half-maximal inhibitory concentration: 829 nM
For compound 3 the middle estimate is 83-fold (1.92 log units) below the measured one; the whole stated range lies below it.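

This position is far from indifferent to the group it carries. In this assay, among these compounds, the exchange of 4-methylphenyl for 1-methyl-1H-indol-6-yl, on an aromatic carbon of the five-membered ring with 2 nitrogen, gives a 280-fold higher number from compound 1 to compound 3 (2.44 log units; beyond the scatter) and is the first measured change at this place. Nothing given here accounts for the size of this loss.

On these data alone, it remains open whether the second fused ring, its nitrogen or the N-methyl group drives the loss. As far as these compounds go, how a phenyl ring bearing an amine or a carboxylic acid would behave here also remains open.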